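Swapping the benzyl substituent on a weak antiproliferative triazolopyrimidine

The compounds below may be only part of what the source reports. "The series", "measured", "known", "first", "only" and "open" are said of these compounds alone.

Measured compounds:
- compound 1 `CCCSc1nc(N/N=C(\C)c2ccc(O)cc2)c2nnn(Cc3ccccc3)c2n1`: 16700 nM
- compound 2 `CCCSc1nc(N/N=C/c2ccccc2Cl)c2nnn(Cc3ccccc3)c2n1`: 10900 nM
- compound 3 `CCCSc1nc(N/N=C(\C)c2ccccc2O)c2nnn(Cc3ccccc3Cl)c2n1`: 35000 nM

In a functional assay on MGC-803 cells (Homo sapiens) for antiproliferative activity, read by MTT assay, with a stated time of 72 h (a lower number here means a stronger inhibitor, a higher number a weaker inhibitor), compound 3 gives the highest number of the three, that is the weakest inhibition; compound 1 sits closer to it and compound 2 furthest away, both gaps beyond the scatter. Compound 4 `CCCSc1nc(N/N=C(\C)c2ccccc2O)c2nnn(Cc3ccc(F)cc3)c2n1` differs from compound 3 in one place: 4-fluorophenyl in place of 2-chlorophenyl on a saturated chain carbon bound to an aromatic nitrogen. Within the data shown here, no measured pair changes that benzyl group alone. Among the measured compounds shown here, the only single-place step on record, a 1.5-fold lower number from compound 1 to compound 2 (0.19 log units; within the scatter), alters the hydrazone-bearing arm instead and stays within the scatter, so it says nothing direct about the benzyl end. Compounds 1 and 2 carry a plain benzyl and give lower numbers than compound 3, but they also differ from it elsewhere, so the halogen on the benzyl cannot be singled out. For the measured compounds named here, with no bearing step, compound 4 is expected to land near compound 3, the estimated step being a 1.4-fold lower number from compound 3 to compound 4 (0.15 log units; within the scatter). Compound 4 is therefore estimated at 25000 nM, with a range from 9000 nM to 70000 nM.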

Compound 4, half-maximal inhibitory concentration: 11000 nM
Beside the measured number, compound 4's estimate is 2.3-fold (0.36 log units) above it; low and high end bracket the measured number.
By their numbers in this assay, from the lowest: compounds 2, 4 and 1 (each within the scatter of the next); then compound 3.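

In this assay, among these compounds, the change from 2-chlorobenzyl to 4-fluorobenzyl gives a 3.2-fold lower number from compound 3 to compound 4 (0.50 log units; beyond the scatter) and is the first step at the benzyl end on record, and it lies beyond the scatter. This shows that the position, on a saturated chain carbon bound to an aromatic nitrogen, is sensitive to what the phenyl ring carries, even though both groups count the same number of heavy atoms. No available data explain the shift.

The halogen and its place on the ring change together in this one step, so the effect of each remains unresolved. As far as these compounds go, it also remains open how this same compound would respond to a plain benzyl group, or to a benzyl ring carrying a methoxy group or an amine.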